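Chlorine-bearing series: carbamate to methyl on the pyridine

The source may report more compounds than this note shows. Statements on the series, on what has been measured and on what is new or still open speak of the compounds shown alone.

Four compounds share one core. Compound 1 `Cc1cc(-c2cc(C)c(OC[C@@](C)(N)CC(C)C)cn2)ccn1`, compound 2 `COC(=O)Nc1cc(-c2ccc(OC[C@@](C)(N)CC(C)C)c(C)c2)ccn1` and compound 3 `COC(=O)Nc1cc(-c2cc(Cl)c(OC[C@@](C)(N)CC(C)C)cn2)ccn1` have been measured in an ADME assay on microsomes from liver (Mus musculus) for metabolic stability, read by LC-MS, using NADPH, with a stated time of 10 min, tested at 0.5 uM; a higher number here means that more of the compound is left, a lower number that less of the compound is left. Compound 1 gives 72%. Compound 2 gives 75%. Compound 3 gives 87%, the highest of the three numbers; compound 2 lies below it by more than the usual scatter, and compound 1 lies further below, also by more than the scatter. No two of these three differ in one place only, so no single structural step can be read from them.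

Compound 4 `Cc1cc(-c2cc(Cl)c(OC[C@@](C)(N)CC(C)C)cn2)ccn1` has not yet been measured. It differs from compound 3 as follows: methyl in place of (methoxycarbonyl)amino on an aromatic carbon. The change sits on an aromatic carbon of a six-membered aromatic ring with one nitrogen, next to the ring nitrogen, meta to a large group.

For the step of a number 8 percentage points lower from compound 3 to compound 4 (within the scatter) a small decrease is expected, about the size of the scatter, since compound 1 with its methyl gives 72% and so sits below the carbamate-bearing compound 3. For compound 4 the estimated value is 79%, within a range from 64% to 92%.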

Compound 4, percent of the compound remaining: 71%
The estimate for compound 4 lay 8 percentage points above the measured number; the range from low to high includes it.
By their numbers in this assay, from the lowest: compounds 4, 1 and 2 (each within the scatter of the next); then compound 3.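

In this assay, going by these compounds alone, methyl in place of (methoxycarbonyl)amino, next to the ring nitrogen, gives a number 16 percentage points lower from compound 3 to compound 4 (beyond the scatter) with chloro held constant; this is the first single-place reading at this position, and it shows more of the compound left with (methoxycarbonyl)amino than with methyl. With methyl at this position, chloro in place of methyl on an aromatic carbon gives a number 1 percentage points lower from compound 1 to compound 4 (within the scatter) and so shows no difference beyond the scatter. No evidence on the origin of either step is at hand.

Going by these compounds, it remains open whether the whole (methoxycarbonyl)amino group is needed for this step, or whether a free amine or an acetylamino group at this position would give a similar number. On these data alone, it is also open whether chloro in place of methyl would read the same with (methoxycarbonyl)amino at this position.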